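Indole thioether series: N-methoxy on the piperidine nitrogen

This account rests on a few compounds, and the source may have more. Where it says the series, first, only, none or still open, it means among the compounds named here.

Measured so far:
compound 1 `Clc1ccc2[nH]cc(SC3CCNCC3)c2c1`, 0.3 mg/kg
compound 2 `Cc1[nH]c2ccc(Cl)cc2c1SC1CCNCC1`, 0.8 mg/kg
compound 3 `CN1CCC(Sc2cn(C)c3ccc(Cl)cc23)CC1`, 3.9 mg/kg

In a functional assay on the whole organism with Mus musculus as the target, in the writhing test (a higher number here means that more compound is needed for the effect, a lower number that less compound is needed), compound 1 gives the lowest number of the three; compound 2 lies nearest, and compound 3 furthest. For the measured compounds named here, the one single-point step known is a 2.7-fold higher number from compound 1 to compound 2 (0.43 log units; beyond the scatter), a methyl on an aromatic carbon. Compound 4 `CON1CCC(Sc2c[nH]c3ccc(Cl)cc23)CC1` differs from compound 1 by methoxy in place of hydrogen on an amine nitrogen in a ring. Going by the values given here, no measured step touches that nitrogen, so the methyl step is only a weak guide, and compound 3 carries two changes at once and cannot be separated. Compound 4 is therefore expected to move as a 3.3-fold higher number from compound 1 to compound 4 (0.52 log units; beyond the scatter), with wide uncertainty. The estimate for compound 4 in this assay is 1 mg/kg, from 0.3 mg/kg to 4 mg/kg.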

Compound 4, dose for half-maximal effect: 1.4 mg/kg
Compound 4: middle estimate off by 1.4-fold (0.15 log units), on the low side, and the stated range covers the measured number.
By their numbers in this assay, from the lowest: compound 1; then compounds 2 and 4 (each within the scatter of the next); then compound 3.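

In this assay, for the compounds shown here, this is the first reading at the amine nitrogen in the ring: methoxy in place of hydrogen gives a clear loss (a 4.7-fold higher number from compound 1 to compound 4 (0.67 log units; beyond the scatter)). The substituted nitrogen still gives a dose in the low range of the series, with compound 4 at 1.4 mg/kg. Nothing shown bears on why the step has this size.

Compound 3 carries a methyl on that nitrogen together with a second change, so the methyl alone cannot be read. On these data alone, whether ethoxy or hydroxy on that nitrogen would give a step of similar size remains open.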